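From trifluoromethyl to trifluoromethoxy in compound 4

The source may hold more compounds than are shown below. What is called first, only, known or untested is meant among the compounds shown, and "the series" means these compounds.

In a functional assay on VCaP cells (Homo sapiens) for antiproliferative activity, read by fluorescence and propidium iodide staining, with a stated time of 96 h (a lower number here means a stronger inhibitor, a higher number a weaker inhibitor), compound 1 (`CC(O)(CSc1ccccc1OC(F)(F)F)C(=O)Nc1cc(C(F)(F)F)cc(C(F)(F)F)c1`) gives 2900 nM and compound 2 (`CC(O)(COc1cc(C(F)(F)F)cc(C(F)(F)F)c1)C(=O)Nc1ccc(C(F)(F)F)cc1`) gives 4150 nM as its value. Compound 3 (`CC(O)(CS(=O)(=O)c1ccccc1C(F)(F)F)C(=O)Nc1cc(C(F)(F)F)cc(C(F)(F)F)c1`) has the highest number of the three, 8550 nM in this assay, and its gaps to both others lie beyond the usual scatter.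

Compound 4 (`CC(O)(CS(=O)(=O)c1ccccc1OC(F)(F)F)C(=O)Nc1cc(C(F)(F)F)cc(C(F)(F)F)c1`) differs from compound 3 in one place (trifluoromethoxy in place of trifluoromethyl on an aromatic carbon), with trifluoromethoxy in place of trifluoromethyl on an aromatic carbon. Among the measured compounds shown here, no pair of measured compounds shows this change alone, so its size is not known directly. For the measured compounds named here, the only guide is compound 1, which also carries 2-(trifluoromethoxy)phenyl and reads 2900 nM in this assay, although it differs from compound 4 elsewhere as well. A small step toward a lower number is therefore expected, possibly no larger than the scatter. The estimated change a 1.4-fold lower number from compound 3 to compound 4 (0.15 log units; within the scatter) is of that modest kind. For compound 4 the expected value is 6000 nM (estimated range 2500 nM to 14000 nM), still to be measured.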

Compound 4, half-maximal inhibitory concentration: 9950 nM
The estimate for compound 4 lay 1.7-fold (0.22 log units) below the measured number; the measured number falls inside the stated range.
By their numbers in this assay, from the lowest: compounds 1 and 2 (each within the scatter of the next); then compounds 3 and 4 (each within the scatter of the next).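

In this assay, the step from 2-(trifluoromethyl)phenyl to 2-(trifluoromethoxy)phenyl is now measured directly, as a 1.2-fold higher number from compound 3 to compound 4 (0.07 log units; within the scatter). At this position, on an aromatic carbon ortho to a large group, the two groups cannot be told apart in this assay, even though trifluoromethoxy brings one more heavy atom and one hydrogen-bond acceptor. Nothing available explains why the swap leaves the reading within the scatter.

The compounds shown leave open whether a different group at this position, such as a chlorine atom, a nitrile or a methoxy group, would move the number beyond the scatter. They also leave open whether the same swap would read alike with a thioether or an ether in place of the sulfonyl group.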